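This account rests on a few compounds, and the source may have more. Where it says the series, first, only, none or still open, it means among the compounds named here.

Measured compounds:
- compound 2 `COc1ccc(Cn2cc3cc(C(=N)Nc4ccc(N5CCN(C)CC5)cc4)ncc3n2)cc1`: 3200 nM
- compound 3 `COc1ccc(Cn2cc3cc(C(=N)Nc4cccc(C(F)(F)F)c4)ncc3n2)cc1`: 13000 nM
- compound 1 `COc1ccc(Cn2nc(-c3ccccc3)c3cc(C(=N)Nc4cccc(C(F)(F)F)c4)nc(NC4CCCCC4)c32)cc1`: "not determined" (no result reported)

In a functional assay on HT-1080 cells (Homo sapiens) for cytotoxicity, read by MTT assay, with a stated time of 72 h (a lower number here means a stronger inhibitor, a higher number a weaker inhibitor), compound 2 gives 3200 nM, the lowest of the two numbers shown. Compound 3 gives 13000 nM, a higher number, and the gap to compound 2 lies beyond the scatter. Compound 1 has no result in this assay.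

Compound 4 `CN1CCN(c2ccc(NC(=N)c3cc4cn(C)nc4cn3)cc2)CC1` is not yet measured. It differs from compound 2 by hydrogen in place of 4-methoxyphenyl on a saturated chain carbon bound to an aromatic nitrogen. Going by the values given here, no step between measured compounds covers this change, so the expectation rests only on compound 2 and its 3200 nM. A modest loss of potency in this assay is expected from compound 2 to compound 4, perhaps not beyond the scatter; the expected step is a 1.7-fold higher number from compound 2 to compound 4 (0.24 log units; within the scatter). Compound 4 is estimated at 5500 nM, within 1800 nM to 20000 nM.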

Compound 4, half-maximal inhibitory concentration: 21000 nM
Estimate against measurement, compound 4: 3.8-fold (0.58 log units) below, outside the stated range (above it).
By their numbers in this assay, from the lowest: compound 2; then compounds 3 and 4 (each within the scatter of the next).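

In this assay, hydrogen in place of 4-methoxyphenyl on a saturated chain carbon bound to an aromatic nitrogen gives a 6.6-fold higher number from compound 2 to compound 4 (0.82 log units; beyond the scatter). Going by these compounds alone, the earlier compounds all carry 4-methoxybenzyl there, so this is the first sign that the number depends on this position. No measurement at hand explains the rise.

Open, on these data alone, is whether a plain benzyl, an ethyl or a longer alkyl chain would keep the number of compound 2 or that of compound 4. Also open, as far as these compounds go, is whether the same step holds with the trifluoromethyl group of compound 3.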